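The compounds below may be only part of what the source reports. "The series", "measured", "known", "first", "only" and "open" are said of these compounds alone.

Compound 1 `Cc1sc2c(Nc3cccnc3)cccc2c1C` and compound 2 `COc1ccc(Nc2cccc3c(C)c(C)sc23)cc1` share one core and differ only in the aryl group carried on the ring nitrogen. In a functional assay for inhibition, with a stated time of 2 h, tested at 0.250 g/L (on this read-out higher numbers stand for more inhibition at the one concentration tested (going by the name of the read-out) and lower numbers for less inhibition), compound 1 gives 86.2%, the lower of the two values in hand. In this assay compound 2 gives 100%, a result that lies beyond the usual scatter above that of compound 1, so compound 1 stands at the bottom of what has been measured so far.

Compound 3 `Cc1sc2c(Nc3ccccn3)cccc2c1C` has not yet been measured. It is built from compound 1 by the change (pyridin-2-yl in place of pyridin-3-yl on a nitrogen on an aromatic ring). For the measured compounds named here, nothing in the two measured compounds bears on this kind of rearrangement, since both of them carry their pyridine or methoxyphenyl group in a different way, and so no step of known size guides the expectation.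

The step from compound 1 to compound 3 in this assay is therefore expected to be small, a number 8.2 percentage points lower from compound 1 to compound 3 (within the scatter), and not clearly beyond the scatter in either direction. Compound 3 is estimated to give 78% in this assay, within a range from 50% to 100%.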

Compound 3, a percentage reported as inhibition, at one concentration (the size of the read-out at that concentration, not a potency): 47.2%
Compound 3: middle estimate off by 30.8 percentage points, on the high side; the measured number lies below the stated range.
By their numbers in this assay, from the lowest: compound 3; then compound 1; then compound 2.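

Pyridin-2-yl in place of pyridin-3-yl on a nitrogen on an aromatic ring leaves the atoms unchanged and alters only how they are joined, yet in this assay this change comes with a number 39 percentage points lower from compound 1 to compound 3 (beyond the scatter) on the shared core. The counts of heavy atoms, hydrogen-bond donors and hydrogen-bond acceptors are the same for the two groups, so these counts do not separate them, while the read-out does. Nothing measured here accounts for the size of this step.

The compounds shown leave open how a pyrimidine, or a pyridine carrying an amine, would stand on the same nitrogen. They also leave open whether this exchange would go the same way with ethyl groups in place of the methyl groups on the core, as the step is seen only once.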